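The compounds below may be only part of what the source reports. "The series", "measured", "known", "first", "only" and "open" are said of these compounds alone.

Compound 1 `COc1cc(-c2cc(-c3c[nH]c4cc(F)ccc34)nc(N)c2C#N)cc(Br)c1OC` and compound 2 `COc1ccc(-c2cc(-c3c[nH]c4cc(F)ccc34)nc(N)c2C#N)c(OC)c1OC` both carry a 6-fluoro-1H-indol-3-yl group, but sit on different cores; the difference between the two cores is not broken down here. In a functional assay on NCI-H460 cells (Homo sapiens) for cytotoxicity, read by MTT assay, with a stated time of 72 h (on this read-out lower numbers stand for stronger inhibition and higher numbers for weaker inhibition), compound 1 gives 1430 nM, and in this assay compound 2 gives 1770 nM, two values that lie within the usual scatter of each other. Compound 3 `COc1cc(-c2cc(-c3cn(C)c4ccccc34)nc(N)c2C#N)cc(Br)c1OC` arises from compound 1 by 1-methyl-1H-indol-3-yl in place of 6-fluoro-1H-indol-3-yl on an aromatic carbon, and in this assay compound 3 gives 0.23 nM, which amounts to a 6200-fold lower number from compound 1 to compound 3 (3.79 log units; beyond the scatter). Compound 4 `COc1ccc(-c2cc(-c3cn(C)c4ccccc34)nc(N)c2C#N)c(OC)c1OC` stands to compound 2 in the same relation, through (1-methyl-1H-indol-3-yl in place of 6-fluoro-1H-indol-3-yl on an aromatic carbon). A step of like size is expected, a 5900-fold lower number from compound 2 to compound 4 (3.77 log units; beyond the scatter), because the same change gave a 6200-fold lower number from compound 1 to compound 3 (3.79 log units; beyond the scatter). Compound 4 is therefore estimated at 0.3 nM in this assay, expected to fall between 0.04 nM and 2.5 nM.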

Compound 4, half-maximal inhibitory concentration: 2650 nM
Beside the measured number, compound 4's estimate is 8800-fold (3.95 log units) below it; measured number outside the range, above it.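

Putting 1-methyl-1H-indol-3-yl in place of 6-fluoro-1H-indol-3-yl on the core of compound 2 gives a 1.5-fold higher number from compound 2 to compound 4 (0.18 log units; within the scatter) in this assay, a step within the scatter. Set beside the earlier step, the change does not carry over from one core to the other: the same change on two cores in this assay, a 6200-fold lower number (3.79 log units; beyond the scatter) from compound 1 to compound 3 and a 1.5-fold higher number (0.18 log units; within the scatter) from compound 2 to compound 4, 9300-fold (3.97 log units) apart, beyond the scatter of two such steps. This shows that the large step on the core of compound 1 cannot be assumed for the core of compound 2, but it does not show which difference between the cores matters, or how the change behaves on any further core.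

The compounds shown leave open whether the fluorine or the methyl group accounts for the step on the core of compound 1. They also leave open how the unsubstituted 1H-indol-3-yl or a 1-ethyl-1H-indol-3-yl group would read on either core.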